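This account rests on a few compounds, and the source may have more. Where it says the series, first, only, none or still open, it means among the compounds named here.

Compound 2 `COc1ccc(CNc2nc3cc(N)cc(N)c3nc2-c2ccccc2)cc1OC` stands highest of the two numbers in a functional assay on UACC-257 cells (Homo sapiens) for inhibition, read by sulforhodamine B assay, with a stated time of 48 h; on this read-out higher numbers stand for weaker inhibition of growth and lower numbers for stronger inhibition of growth: compound 2 gives 12900 nM, while compound 1 `Nc1cc(N)c2nc(-c3ccccc3)c(NCc3ccc(Cl)c(Cl)c3)nc2c1` gives 4570 nM. Going by the values given here, the single measured step, a 2.8-fold higher number from compound 1 to compound 2 (0.45 log units; beyond the scatter), is modest. Compound 3 `COc1cc(CNc2nc3cc(N)cc(N)c3nc2-c2ccccc2)cc(OC)c1OC` differs from compound 2 by methoxy in place of hydrogen on an aromatic carbon. Among the compounds with values here, no measured step swaps hydrogen for methoxy, so the step from compound 1 to compound 2 bears on it only loosely, as a sign that changes on this ring move the number modestly. The step is therefore expected to be a 1.1-fold higher number from compound 2 to compound 3 (0.04 log units; within the scatter), likely within the scatter. Compound 3 is estimated at 14000 nM, between 6000 nM and 35000 nM.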

Compound 3, concentration for 50% growth inhibition: 3470 nM
Compound 3: middle estimate off by 4.0-fold (0.61 log units), on the high side; the whole stated range lies above it.
By their numbers in this assay, from the lowest: compounds 3 and 1 (each within the scatter of the next); then compound 2.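

Methoxy in place of hydrogen on the aromatic carbon, ortho to a methoxy group and meta to a large group, gives a 3.7-fold lower number from compound 2 to compound 3 (0.57 log units; beyond the scatter) in this assay, a move toward stronger inhibition of growth. Going by these compounds alone, the earlier pair showed only one set of ring groups exchanged for another, whereas this step shows that adding one group at this position can shift the number. Nothing at hand accounts for the step. Still open, on these data alone, is whether a hydroxy group, a fluorine or an ethoxy group on this carbon would move the number as methoxy does.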